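Ethoxy for Methoxy on the Ring of a Hydrazone

This account rests on a few compounds, and the source may have more. Where it says the series, first, only, none or still open, it means among the compounds named here.

Four compounds share one core and differ only in the ring carried on the amine nitrogen. Compound 1 `COc1ccccc1N/N=C1\CCC(C)n2c1ncc(C(=O)O)c2=O` and compound 2 `COc1ccc(N/N=C2\CCC(C)n3c2ncc(C(=O)O)c3=O)cc1` differ by 4-methoxyphenyl in place of 2-methoxyphenyl on an amine nitrogen. In a functional assay on the whole organism for inhibition, with Rattus norvegicus as the target (a higher number here means that more compound is needed for the effect, a lower number that less compound is needed), compound 1 reaches only the limit > 1000 umol/kg. Compound 2 gives 7.6 umol/kg in this assay, which is an at least 130-fold lower number from compound 1 to compound 2 (2.11 log units; beyond the scatter). Compound 3 `CCOc1ccccc1N/N=C1\CCC(C)n2c1ncc(C(=O)O)c2=O` arises from compound 1 by methyl in place of hydrogen on a saturated chain carbon bound to an oxygen on an aromatic ring. In this assay compound 3 also stops at the limit > 1000 umol/kg. Due to the limit of > 1000 umol/kg in this assay, at which 2 of the 3 values shown sit, this yields a step that the two limits leave unreadable from compound 1 to compound 3. Compound 4 `CCOc1ccc(N/N=C2\CCC(C)n3c2ncc(C(=O)O)c3=O)cc1` arises from compound 2 by methyl in place of hydrogen on a saturated chain carbon bound to an oxygen on an aromatic ring, the same change made from compound 1 to compound 3, at the same place. That earlier step gives no usable size, so the expectation for compound 4 rests on the value of compound 2 7.6 umol/kg and on the single heavy atom that enters. Compound 4 is therefore expected to give about 15 umol/kg in this assay, with a range from 3 umol/kg to 100 umol/kg. That estimate means an expected step of a 2.0-fold higher number from compound 2 to compound 4 (0.30 log units; within the scatter).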

Compound 4, dose for 50% inhibition: > 100 umol/kg
Compound 4 gave a limit, no number; the forecaster's own chance of this, stated with the estimate: 10%; middle value at least 6.6-fold (0.82 log units) from the limit.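

In this assay, putting ethoxy in place of methoxy on the 4-methoxyphenyl compound gives an at least 13-fold higher number from compound 2 to compound 4 (1.11 log units; beyond the scatter), a large step for the one methyl that enters, and this is the only readable measure of the change in these compounds. As far as these compounds go, compound 4 stands at > 100 umol/kg, which is a limit and not a number, so the full size of the step stays unknown. This shows that the change matters on the 4-methoxyphenyl compound, but it does not show whether the effect carries over to the 2-methoxyphenyl compounds, because the matching step from compound 1 to compound 3 cannot be read: the limit of > 1000 umol/kg in this assay, at which 2 of the 4 values shown sit.

The compounds shown leave open how a longer chain such as propoxy, or a hydroxyl group in place of the methoxy, would behave on the 4-methoxyphenyl ring. They also leave open whether the dose rises steadily as the chain grows, since only methoxy and ethoxy appear here and only compound 2 has a true number.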